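Enlarging the Amide Substituent on a Chemokine Receptor Antagonist

The compounds below may be only part of what the source reports. "The series", "measured", "known", "first", "only" and "open" are said of these compounds alone.

Compound 1, `CNC(=O)c1cnc(N2CCN(C3CCN(Cc4ccccn4)CC3)[C@@H](C)C2)c(Cl)c1`: 7990 nM
Compound 2, `CNC(=O)c1cnc(N2CCN(C3CCN(Cc4ccc(F)cc4Cl)CC3)[C@@H](C)C2)c(Cl)c1`: 58 nM
Compound 3, `CC(=O)c1cnc(N2CCN(C3CCN(Cc4ccc(Cl)cc4)CC3)[C@@H](C)C2)c(Cl)c1`: 520 nM

In a functional assay for antagonist activity at C-X-C chemokine receptor type 3 (Homo sapiens) (a lower number here means a stronger inhibitor, a higher number a weaker inhibitor), compound 3 stands second highest of the three numbers, between compound 1 and compound 2. Compound 4, `C[C@H]1CN(c2ncc(C(=O)NCC3CCCCC3)cc2Cl)CCN1C1CCN(Cc2ccc(Cl)cc2)CC1`, differs from compound 3 in one place: (cyclohexylmethyl)amino in place of methyl on a carbonyl carbon. Among the measured compounds shown here, the only measured step, a 140-fold lower number from compound 1 to compound 2 (2.14 log units; beyond the scatter), concerns the aromatic group on the chain carbon bound to the ring amine, not the carbonyl substituent, so it does not bear directly on this change. Compound 2 and compound 3 differ in two places at once, so their values cannot separate the effect of the carbonyl substituent. For the measured compounds named here, with no direct precedent, a modest step is expected: a 2.6-fold lower number from compound 3 to compound 4 (0.41 log units; beyond the scatter). Compound 4 is estimated at 200 nM, within a range of 40 nM to 1000 nM.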

Compound 4, half-maximal inhibitory concentration: 2.4 nM
Compound 4: the middle estimate sits 83-fold (1.92 log units) above what was measured; the whole stated range lies above it.
By their numbers in this assay, from the lowest: compound 4; then compound 2; then compound 3; then compound 1.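

The carbonyl carbon proves to be a position where the substituent matters greatly: in this assay, (cyclohexylmethyl)amino in place of methyl gives a 220-fold lower number from compound 3 to compound 4 (2.34 log units; beyond the scatter). This one change brings in the amide hydrogen and the six-membered carbon ring together, so the step alone cannot show which of them counts. Nothing measured here explains the size of this step.

From the compounds shown here alone, it remains open whether a smaller group such as ethylamino on the same carbonyl carbon would keep this gain. Benzylamino, with an aromatic ring replacing the cyclohexyl ring, poses the same open question.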